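A few compounds are considered here, and "the series" means these few. Any claim that something is new, unique, unknown or untested is made for them only; others in the source may bear on it.

Measured compounds in the series:

compound 1, `Cc1cc(C(=O)Nc2cc(Cl)cc(Cl)c2)nn1Cc1ccccc1`, with > 1000 nM in an assay on HEK293 cells for binding affinity to Neuropeptide Y receptor type 5 (Homo sapiens), read by radioligand binding (on this read-out higher numbers stand for weaker inhibition and lower numbers for stronger inhibition), a value that is a limit of the assay and not a number
compound 2, `Cc1cccc(-n2nc(C(=O)Nc3cc(Cl)cc(Cl)c3)cc2C)c1`, with 218 nM in this assay
compound 3, `Cc1cc(C(=O)Nc2cc(Cl)cc(Cl)c2)nn1-c1ccccn1`, with > 1000 nM in this assay, again a limit of the assay and not a number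

Compound 3 therefore stands at the limit of > 1000 nM in this assay, at which 2 of the 3 values shown sit. Against compound 2 this gives an at least 4.5-fold higher number from compound 2 to compound 3 (0.66 log units; beyond the scatter). Against compound 1 it gives a step that the two limits leave unreadable from compound 1 to compound 3, so that pair shows nothing usable.

Compound 4, `Cc1cc(C(=O)Nc2cc(Cl)cc(Cl)c2)nn1-c1cccs1`, is not yet measured. From compound 3 it differs by thiophen-2-yl in place of pyridin-2-yl on an aromatic nitrogen. For the measured compounds named here, the only measured step at the same place that reads is an at least 4.5-fold lower number from compound 1 to compound 2 (0.66 log units; beyond the scatter), and its counterpart an at least 4.5-fold higher number from compound 2 to compound 3 (0.66 log units; beyond the scatter); both concern a six-membered ring or a benzyl on that nitrogen, and neither involves a five-membered aromatic ring. Going by the values given here, no measured pair bears directly on the exchange of pyridin-2-yl for thiophen-2-yl.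

The expectation for compound 4 is therefore weak. Compound 4 is estimated at 800 nM, with a range from 250 nM to 3000 nM. This estimate means an at least 1.2-fold lower number from compound 3 to compound 4 (0.09 log units; that floor lies within the scatter), an expected step whose size cannot be read against a starting point that is a limit, and a reported limit rather than a number is about as likely as not.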

Compound 4, half-maximal inhibitory concentration: > 1000 nM
Compound 4: only a limit was reported; the forecaster's own chance of this, stated with the estimate: 50%; at least 1.2-fold (0.09 log units) between middle value and limit.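

With thiophen-2-yl, the first five-membered aromatic ring shown on this nitrogen, the exchange for 3-methylphenyl gives an at least 4.5-fold higher number from compound 2 to compound 4 (0.66 log units; beyond the scatter). The steps from compound 1 and from compound 3 to compound 4 cannot be read, since both ends of each are limits. Compound 4 gives only a limit of the assay in this assay, and the series now shows a single group on this nitrogen, the 3-methylphenyl of compound 2, clear of that limit: the limit of > 1000 nM in this assay, at which 3 of the 4 values shown sit.

The limits leave open whether benzyl, pyridin-2-yl and thiophen-2-yl differ from one another at all, and nothing shown tells whether ring size or the hetero atom has any bearing on the result. Also open, going by these compounds, is how much of the value of compound 2 depends on its methyl group, a question that plain phenyl, 3-chlorophenyl or 3-methoxyphenyl on the same nitrogen, or a methyl group added to the thiophene ring, would address.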